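Shortening the acyl chain on a dioxolane thymine nucleoside analogue

A few compounds are considered here, and "the series" means these few. Any claim that something is new, unique, unknown or untested is made for them only; others in the source may bear on it.

Measured so far:
compound 1, `Cc1cn([C@H]2CO[C@@H](COC(=O)C(C)(C)C)O2)c(=O)[nH]c1=O`: 18100 nM
compound 2, `CCCCCCCCCCCCCCCC(=O)OC[C@@H]1OC[C@H](n2cc(C)c(=O)[nH]c2=O)O1`: 92200 nM

Both compounds share the same core and differ only in the group attached through the carbonyl. In an ADME assay on Vero cells (Chlorocebus sabaeus) for cytotoxicity, read by MTT assay, with a stated time of 3 days (on this read-out higher numbers stand for weaker inhibition and lower numbers for stronger inhibition), compound 1 gives 18100 nM, while compound 2 gives the highest number of the two, 92200 nM, a gap that lies beyond the usual scatter. So compound 2, carrying the long saturated chain, is the weaker inhibitor of cell viability of the pair.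

Compound 3, `CCCCC(=O)OC[C@@H]1OC[C@H](n2cc(C)c(=O)[nH]c2=O)O1`, has not yet been measured. It differs from compound 2 by hydrogen in place of undecyl on a saturated chain carbon, four bonds along the chain from a carbonyl carbon. Since compound 1, with a small group on the carbonyl, gives 18100 nM, a shortened chain is expected to move the number downward, toward compound 1, though perhaps not all the way. The expected step in this assay from compound 2 to compound 3 is therefore a moderate drop, a 2.9-fold lower number from compound 2 to compound 3 (0.46 log units; beyond the scatter). Compound 3 is estimated to give 32000 nM, within a range from 12000 nM to 85000 nM.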

Compound 3, half-maximal inhibitory concentration: 49000 nM
The estimate for compound 3 lay 1.5-fold (0.19 log units) below the measured number; the measured number falls inside the stated range.
By their numbers in this assay, from the lowest: compound 1; then compounds 3 and 2 (each within the scatter of the next).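

In this assay, hydrogen in place of undecyl on a saturated chain carbon, four bonds along the chain from a carbonyl carbon, amounts to a 1.9-fold lower number from compound 2 to compound 3 (0.27 log units; within the scatter), so removing this long stretch of chain leaves no change that can be told apart from ordinary assay noise. The comparison with the other short ester is different: butyl in place of tert-butyl on a carbonyl carbon gives a 2.7-fold higher number from compound 1 to compound 3 (0.43 log units; beyond the scatter), a modest step but a readable one, which shows that shortening the chain does not by itself bring the number to that of compound 1, and that the group on the carbonyl carbon can still shift this cytotoxicity reading. No measurement is available here that bears on why these two changes differ in size.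

The compounds shown leave open whether a different group on the carbonyl carbon, such as methyl or phenyl, would fall nearer compound 1 or compound 3. They also leave open whether a group carrying an amine or a carboxylic acid on that carbon would move the number further than any of these hydrocarbon groups.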